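The source may hold more compounds than are shown below. What is called first, only, known or untested is meant among the compounds shown, and "the series" means these compounds.

Three compounds of one series have been run through an ADME assay on the whole organism (Rattus norvegicus, strain Wister-Han) for pharmacokinetics, read by LC-MS, at a dose of 3 mg/kg by the oral route (on this read-out lower numbers stand for lower exposure and higher numbers for higher exposure at the dose given), and they share a core that differs only in the side group hanging off a small ring. Compound 1 `CCS(=O)(=O)N1CCC(c2cncc(N3C(=O)c4ccc(Cl)cc4C3(C)C)c2)CC1` carries a six-membered ring and gives 1470 ng.h/mL. Compound 2 `CCS(=O)(=O)N1CC(Oc2cncc(N3C(=O)c4ccc(Cl)cc4C3(C)C)c2)C1` puts the same ethylsulfonyl on a four-membered ring joined through an oxygen, and in this assay compound 2 gives 6370 ng.h/mL, the highest of the three numbers. Compound 3 `Cn1cc(C(=O)N2CC3(C2)CN(c2cncc(N4C(=O)c5ccc(Cl)cc5C4(C)C)c2)C3)cn1` replaces the ethylsulfonyl with a (1-methyl-1H-pyrazol-4-yl)carbonyl on a spiro ring and gives 5660 ng.h/mL; this sits within the usual scatter of compound 2, while compound 1 lies well beyond it on the low side.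

Compound 4 `Cn1cc(C(=O)N2CC(Oc3cncc(N4C(=O)c5ccc(Cl)cc5C4(C)C)c3)C2)cn1` has not yet been measured. It takes the four-membered ring of compound 2 and makes one change: (1-methyl-1H-pyrazol-4-yl)carbonyl in place of ethylsulfonyl on an amine nitrogen in a ring. Nothing measured moves exactly this group on exactly this ring, so the expectation rests on compound 3, whose value 5660 ng.h/mL shows that the entering group can sit on a ring amine without a large loss of exposure. The step from compound 2 to compound 4 is therefore expected to be small, a 1.4-fold lower number from compound 2 to compound 4 (0.15 log units; within the scatter), and not beyond the scatter. In this assay compound 4 is estimated at 4500 ng.h/mL, with a range from 1800 ng.h/mL to 11000 ng.h/mL.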

Compound 4, area under the concentration-time curve: 7880 ng.h/mL
Compound 4: middle estimate off by 1.8-fold (0.24 log units), on the low side; the measured number falls inside the stated range.
By their numbers in this assay, from the lowest: compound 1; then compounds 3, 2 and 4 (each within the scatter of the next).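

In this assay, exchanging ethylsulfonyl for (1-methyl-1H-pyrazol-4-yl)carbonyl on the amine nitrogen of the four-membered ring gives a 1.2-fold higher number from compound 2 to compound 4 (0.09 log units; within the scatter), so this read-out does not tell the two groups apart at this position. For the compounds shown here, compound 3 carries the same entering group on a spiro ring, so it differs from the ethylsulfonyl compounds in more than one place and could not show this; compound 2 and compound 4 are the only pair here in which the group alone changes while the ring stays the same. The exchange brings in a five-membered aromatic ring and more heavy atoms, yet exposure at the dose given remains within the scatter, and nothing measured here offers an explanation for that.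

Whether the two groups would also match on the six-membered ring of compound 1, shown here with ethylsulfonyl, stays open. Also open, on these data alone, is what a small acetyl group, a longer propylsulfonyl chain or a plain methyl group would give on the same nitrogen.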